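What Losing a Methoxy Group May Do to Cell Toxicity

The compounds below may be only part of what the source reports. "The series", "measured", "known", "first", "only" and "open" are said of these compounds alone.

In an ADME assay on L6 cells (Rattus norvegicus) for cytotoxicity, read by resazurin assay, with a stated time of 72 h (a higher number here means a weaker inhibitor, a lower number a stronger inhibitor), compound 1 (`COc1ccc2cc(C3=CN4CCC3CC4)ccc2c1`) gives 98800 nM and compound 2 (`C(=C1\CN2CCC1CC2)\c1ccc(C2OCCO2)cc1`) gives 136000 nM as its reading. For the measured compounds named here, these two numbers lie within the usual scatter of each other, so compound 1 stands level with the only other measured compound. Compound 3 (`C1=C(c2ccc3ccccc3c2)C2CCN1CC2`) is still unmeasured. Compared with compound 1, it has hydrogen in place of methoxy on an aromatic carbon and is otherwise unchanged. Going by the values given here, no measured pair isolates this change. Yet compound 2, at 136000 nM despite its much larger structural difference from compound 1, suggests that the reading need not move much, so no step beyond the scatter is expected in this assay in either direction. The estimated step is a 1.1-fold lower number from compound 1 to compound 3 (0.04 log units; within the scatter) and stays small. Compound 3 is expected at 90000 nM within an estimated range from 35000 nM to 200000 nM in this test.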

Compound 3, half-maximal inhibitory concentration: 101000 nM
Compound 3: middle estimate off by 1.1-fold (0.05 log units), on the low side; the measured number falls inside the stated range.
By their numbers in this assay, from the lowest: compounds 1, 3 and 2 (each within the scatter of the next).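

In this assay, for the compounds shown here, hydrogen in place of methoxy on an aromatic carbon gives a 1.0-fold higher number from compound 1 to compound 3 (0.01 log units; within the scatter), and this pair isolates that single change for the first time. At this place on the shared core, a methoxy group and a bare hydrogen therefore cannot be told apart in this test, even though two heavy atoms and a hydrogen-bond acceptor leave with the methoxy group. No supporting measurement accompanies this result, so the pair gives the size of the step but no explanation for it.

As far as these compounds go, only these two groups can be compared here, so the reading with an amine, a carboxylic acid or a longer chain such as butoxy at this place remains open. From the compounds shown here alone, whether other places on the core are equally undemanding also remains open, and compound 2 cannot settle that, as it differs from compound 1 in more than one place.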